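Thromboxane synthase series: phenylsulfonyl replaced by benzyl

The compounds below may be only part of what the source reports. "The series", "measured", "known", "first", "only" and "open" are said of these compounds alone.

Measured in an assay for inhibition of Thromboxane-A synthase (Homo sapiens), using microsomes; a lower number here means a stronger inhibitor, a higher number a weaker inhibitor:
- compound 1, `O=C(O)CC/C=C\CC1COC(c2ccsc2)OC1c1cccnc1`, gives 500 nM
- compound 2, `CC(C)(C1OCC(C/C=C\CCC(=O)O)C(c2cccnc2)O1)S(=O)(=O)c1ccccc1`, gives 40 nM

Compound 2 holds the lower of the two numbers in this assay; compound 1 sits a good deal higher, and the gap between them lies beyond the usual scatter. Going by the values given here, no single-point step between measured compounds is available, so the next change rests on the structures alone.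

Compound 3, `CC(C)(Cc1ccccc1)C1OCC(C/C=C\CCC(=O)O)C(c2cccnc2)O1`, carries benzyl in place of phenylsulfonyl on a saturated chain carbon bound to two saturated chain carbons and a saturated ring carbon. The two acceptor-bearing oxygens of the sulfonyl are gone and a plain aromatic carbon group takes its place.

Expectation: compound 3 is estimated at 100 nM, with a range of 25 nM to 400 nM. The step this estimate means, a 2.5-fold higher number from compound 2 to compound 3 (0.40 log units; beyond the scatter), is expected to run toward a weaker inhibitor by a modest amount, possibly just beyond the scatter, since compound 2 at 40 nM is the only anchor for this position.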

Compound 3, half-maximal inhibitory concentration: 12 nM
The estimate for compound 3 lay 8.3-fold (0.92 log units) above the measured number; the measured number lies below the stated range.
By their numbers in this assay, from the lowest: compound 3; then compound 2; then compound 1.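

In this assay, the position on a saturated chain carbon bound to two saturated chain carbons and a saturated ring carbon tolerates the loss of phenylsulfonyl: benzyl, with 0 hydrogen-bond acceptors against 2, gives a 3.3-fold lower number from compound 2 to compound 3 (0.52 log units; beyond the scatter). The hydrogen-bond acceptors of phenylsulfonyl are therefore not needed for a low number in this pair, and the larger change of 1-benzyl-1-methylethyl in place of thiophen-3-yl on a saturated ring carbon gives a 42-fold lower number from compound 1 to compound 3 (1.62 log units; beyond the scatter). No measured evidence bears on the reason for either step.

The compounds shown do not separate the effect of removing the sulfonyl from that of the extra carbon link to the aromatic ring. From the compounds shown here alone, how a longer chain such as 2-phenylethyl, or an amine on the benzyl ring, would read at this position remains open.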